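The source may report more compounds than this note shows. Statements on the series, on what has been measured and on what is new or still open speak of the compounds shown alone.

Measured in a functional assay on the whole organism for inhibition, with Mus musculus as the target, with a stated time of 1 h, at a dose of 30 mg/kg by the intraperitoneal route; on this read-out higher numbers stand for more inhibition at the one dose given (going by the name of the read-out) and lower numbers for less inhibition:
- compound 1 `O=C(/C=C/C1=Cc2ccccc2OC1)c1ccc(F)cc1`: 65.6%
- compound 2 `O=C(/C=C/C1=Cc2ccccc2OC1)c1ccc(Cl)cc1`: 56.1%
- compound 3 `Cc1ccc(C(=O)/C=C/C2=Cc3ccccc3OC2)cc1`: 53.1%

Compound 3 and compound 2 cannot be told apart on this read-out: a number 3 percentage points lower from compound 2 to compound 3 (within the scatter). Compound 3 is separated from compound 1: a number 12.5 percentage points lower from compound 1 to compound 3 (beyond the scatter). Compound 1 and compound 2, in turn, are not separated: a number 9.5 percentage points lower from compound 1 to compound 2 (within the scatter).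

The next member is compound 4 `CCc1ccc(C(=O)/C=C/C2=Cc3ccccc3OC2)cc1`. The change from compound 3 is methyl in place of hydrogen on a saturated chain carbon bound to an aromatic carbon. Among the compounds with values here, none of the measured steps alters the chain; all three exchange the group on the aromatic carbon itself, and the whole span of those three exchanges barely exceeds the scatter. On these data alone, the methyl of compound 3 is the only carbon substituent measured, so the effect of adding a carbon to it is unknown. Within the data shown here, with no step of the same kind to go by, and the three exchanges small, no step beyond the scatter is expected in this assay ; the expected step is a number 3.1 percentage points lower from compound 3 to compound 4 (within the scatter). Compound 4 is estimated at 50%, within 35% to 65%.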

Compound 4, a percentage reported as inhibition, in the whole organism at one dose (the size of the read-out at that dose, not a potency): 68.1%
For compound 4 the middle estimate is 18.1 percentage points below the measured one; measured number outside the range, above it.
By their numbers in this assay, from the lowest: compounds 3, 2, 1 and 4 (each within the scatter of the next, the first and the last beyond it).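

In this assay, the methyl added to the chain gives a clear gain (a number 15 percentage points higher from compound 3 to compound 4 (beyond the scatter)), so this position responds to a single added carbon more than the spread among the three earlier groups on the aromatic carbon suggested. The ethyl group also separates from chloro (a number 12 percentage points higher from compound 2 to compound 4 (beyond the scatter)) but not from fluoro (a number 2.5 percentage points higher from compound 1 to compound 4 (within the scatter)), so the carbon substituents do not behave as one group: methyl lies beyond the scatter from fluoro, while ethyl does not. Nothing available explains the methyl-to-ethyl step.

Open, on these data alone, is whether a propyl chain or a branched isopropyl group would extend this gain or lose it. Also open, as far as these compounds go, is how a methoxy group or an amine on the aromatic carbon would compare with ethyl, and whether the step holds at other doses.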